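A few compounds are considered here, and "the series" means these few. Any claim that something is new, unique, unknown or untested is made for them only; others in the source may bear on it.

Within the data shown here, in a functional assay on OVCAR-8 cells (Homo sapiens) (a lower number here means a stronger inhibitor of growth, a higher number a weaker inhibitor of growth), compound 2 `O=S(=O)(/C=C/c1ccc(Cl)c(Cl)c1)Cc1ccc(Nc2ncnc3ccccc23)cc1` gives 14000 nM, the higher of the two true numbers so far, while compound 3 `CC(C)(C)c1cc(/C=C/S(=O)(=O)Cc2ccc(Nc3ncnc4ccccc34)cc2)cc(C(C)(C)C)c1O` gives 5000 nM. Compound 1 `N#Cc1ccc(/C=C/S(=O)(=O)Cc2ccc(Nc3ncnc4ccccc34)cc2)cc1` reaches only a limit, > 100000 nM.

Compound 4 `O=S(=O)(/C=C/c1ccc(Cl)cc1Cl)Cc1ccc(Nc2ncnc3ccccc23)cc1` differs from compound 2 as follows: 2,4-dichlorophenyl in place of 3,4-dichlorophenyl on a double-bonded chain carbon bound to a double-bonded chain carbon. It has the same atoms, with 2,4-dichlorophenyl in place of 3,4-dichlorophenyl. Among the measured compounds shown here, the one measured step that bears on this change, an at least 7.1-fold lower number from compound 1 to compound 2 (0.85 log units; beyond the scatter), swaps 4-cyanophenyl for 3,4-dichlorophenyl at this place, so the place does respond. For the measured compounds named here, no measured step compares dichlorophenyl isomers, so no direction can be set. The expected step, a 1.2-fold lower number from compound 2 to compound 4 (0.07 log units; within the scatter), is estimated to stay within the scatter. For compound 4 the estimate is 12000 nM, with an expected range of 4000 nM to 40000 nM.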

Compound 4, concentration for 50% growth inhibition: 4000 nM
For compound 4 the middle estimate is 3.0-fold (0.48 log units) above the measured one, within the range that was stated.
By their numbers in this assay, from the lowest: compounds 4 and 3 (each within the scatter of the next); then compound 2. At a limit, above all of these: compound 1.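

In this assay, moving one chlorine is enough to shift growth inhibition: 2,4-dichlorophenyl in place of 3,4-dichlorophenyl gives a 3.5-fold lower number from compound 2 to compound 4 (0.54 log units; beyond the scatter). The place on the double-bonded chain carbon therefore responds to the arrangement of the chlorines, not only to the choice of group. Replacing 4-cyanophenyl with 2,4-dichlorophenyl gives an at least 25-fold lower number from compound 1 to compound 4 (1.39 log units; beyond the scatter), a step read against a limit for compound 1: the limit of > 100000 nM in this assay, at which 1 of the 4 values shown sits.

Still open, going by these compounds, is whether a single chlorine, as in 2-chlorophenyl or 4-chlorophenyl, would carry the gain. Also open, on these data alone, is how an amine or a carboxylic acid on this ring would behave.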